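The source may report more compounds than this note shows. Statements on the series, on what has been measured and on what is new or still open speak of the compounds shown alone.

Compound 1 `O=C(O)COc1ccc(NC(=O)COc2ccccc2)cc1F` gives 29.8% in a functional assay on CHO cells for agonist activity at Free fatty acid receptor 1 (Homo sapiens), read by FLIPR, tested at 100 nM; on this read-out lower numbers stand for a weaker effect and higher numbers for a stronger effect at the one concentration tested. Compound 2 `CC(C)(C)c1cccc(OCC(=O)Nc2ccc(OCC(=O)O)c(F)c2)c1` gives 40.2%. Compound 3 `CC(Oc1cccc(C(C)(C)C)c1)C(=O)Nc1ccc(OCC(=O)O)c(F)c1` gives 32.8%.

Compound 3 stands second highest of the three numbers, within the scatter of compound 1 and of compound 2. Compound 4 `CC(Oc1cccc(C(F)(F)F)c1)C(=O)Nc1ccc(OCC(=O)O)c(F)c1` differs from compound 3 in one place: trifluoromethyl in place of tert-butyl on an aromatic carbon. Among the compounds with values here, the only measured step touching that aromatic carbon is a number 10.4 percentage points higher from compound 1 to compound 2 (beyond the scatter), which was modest; the step of a number 7.4 percentage points lower from compound 2 to compound 3 (within the scatter) concerns the saturated chain carbon and lies within the scatter. Because a number 10.4 percentage points higher from compound 1 to compound 2 (beyond the scatter) is modest and the exchanged groups share a heavy-atom count, the expected step of a number 2.8 percentage points lower from compound 3 to compound 4 (within the scatter) is small or none beyond the scatter. Compound 4 is therefore expected to give about 30%, between 16% and 46%.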

Compound 4, a percentage reported as activity, at one concentration (the size of the read-out at that concentration, not a potency) in the Free fatty acid receptor 1 assay: 12.7%
For compound 4 the middle estimate is 17.3 percentage points above the measured one; the whole stated range lies above it.
By their numbers in the Free fatty acid receptor 1 assay, from the lowest: compound 4; then compounds 1, 3 and 2 (each within the scatter of the next, the first and the last beyond it).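

In the Free fatty acid receptor 1 assay, the exchange of tert-butyl for trifluoromethyl on this aromatic carbon gives a number 20.1 percentage points lower from compound 3 to compound 4 (beyond the scatter), a modest step that leaves compound 4 at 12.7%, although both groups have the same heavy-atom count. The earlier compounds shown here compared tert-butyl only with hydrogen here, whereas this step shows that the read-out also depends on which group of that count occupies the position. No evidence available here accounts for the step. The step between these two compounds in a physicochemical assay for lipophilicity, using the shake flask method, at pH 7.4 (on this read-out lower numbers stand for lower lipophilicity and higher numbers for higher lipophilicity), cannot be read: compound 3 gives 0.63, and compound 4 is "not determined" (no result reported). On these data alone, how isopropyl or a nitrile at this aromatic carbon would read remains open.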